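The source may report more compounds than this note shows. Statements on the series, on what has been measured and on what is new or still open speak of the compounds shown alone.

Compound 1 `NC1=NC2(CCOCC2)N(OCCCOc2cc(Cl)c(Cl)cc2Cl)C(N)=N1`: > 90%
Compound 2 `Cc1ccc(OCCCON2C(N)=NC(N)=NC23CCOCC3)cc1`: > 90%
Compound 3 `NC1=NC2(CCOCC2)N(OCCCOc2ccccc2Br)C(N)=N1`: 83.8%

In an assay on isolated protein for inhibition of Dihydrofolate reductase (Homo sapiens), read by spectrophotometry, using NADPH, with stated times of 5 s and 6 min, tested at 5 uM (on this read-out lower numbers stand for a weaker effect and higher numbers for a stronger effect at the one concentration tested), compound 1 gives > 90%, which is a limit of the assay and not a number. Compound 2 likewise gives > 90%, again a limit. Among the compounds with values here, compound 3 gives 83.8%, the only plain number among the three; the other two values sit at the limit of > 90% in this assay, at which 2 of the 3 values shown sit. The step that the two limits leave unreadable from compound 1 to compound 2 is therefore unreadable, while a number at least 6.2 percentage points lower from compound 1 to compound 3 (that floor lies within the scatter) and a number at least 6.2 percentage points lower from compound 2 to compound 3 (that floor lies within the scatter) have floors that lie within the usual scatter.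

Compound 4 `Cc1cc(C)cc(OCCCON2C(N)=NC(N)=NC23CCOCC3)c1` has not been measured. It differs from compound 3 as follows: 3,5-dimethylphenyl in place of 2-bromophenyl on an oxygen on a saturated carbon. The step that bears on it most directly is a number at least 6.2 percentage points lower from compound 2 to compound 3 (that floor lies within the scatter), since compound 2 also carries a methylated phenyl on that oxygen; compound 4 reverses the direction of that step with a second methyl added. A rise back toward the limit is expected, small enough that it may not pass beyond the scatter, so a number 4.2 percentage points higher from compound 3 to compound 4 (within the scatter) is the estimated step. Compound 4 is expected to give 88%, between 78% and 95%.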

Compound 4, a percentage reported as inhibition, at one concentration (the size of the read-out at that concentration, not a potency): 84.3%
The estimate for compound 4 lay 3.7 percentage points above the measured number, and the stated range covers the measured number.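

In this assay the exchange of 2-bromophenyl for 3,5-dimethylphenyl on the oxygen gives a number 0.5 percentage points higher from compound 3 to compound 4 (within the scatter) and so separates the two groups by nothing that can be read. Within the data shown here, it is the first step at this position with a plain number at both ends, as every earlier step touched a limit. The steps of a number at least 5.7 percentage points lower from compound 2 to compound 4 (that floor lies within the scatter) and a number at least 5.7 percentage points lower from compound 1 to compound 4 (that floor lies within the scatter) give only floors, and their true size cannot be read because two of the values are limits: (the limit of > 90% in this assay, at which 2 of the 4 values shown sit).

Left open is whether an amine or a carboxylic acid on the phenyl ring, or a longer chain on the oxygen, would keep the read-out in this range. A single concentration also gives no potency for any of the four compounds.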